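Methoxy for Cyclopropyl on a Macrocyclic Aminoquinoline Scaffold

The source may hold more compounds than are shown below. What is called first, only, known or untested is meant among the compounds shown, and "the series" means these compounds.

Compound 2 `CN1Cc2cc(ccc2S(=O)(=O)C2CC2)NC(=O)CCc2cc(ccc2C2CC2)[C@@H](Nc2ccc3c(N)ncc(F)c3c2)C1=O` stands at the top of the three numbers recorded in an ADME assay on liver (Homo sapiens) for metabolic stability, using microsomes (a lower number here means that the compound disappears faster, a higher number that the compound lasts longer), where compound 2 gives 0.433 h. Its closest neighbour is compound 3 `COc1cc2cc(c1)[C@@H](Nc1ccc3c(N)ncc(F)c3c1)C(=O)N(C)Cc1cc(ccc1S(=O)(=O)C1CC1)NC(=O)CC2`, which in this assay gives 0.25 h, a gap that lies within the usual scatter. Compound 1 `CN1Cc2cc(ccc2S(=O)(=O)C2CC2)NC(=O)N(CC2CC2)CCc2cccc(c2)C(Nc2ccc3c(N)ncc(F)c3c2)C1=O` sits furthest away, giving 0.0833 h in this assay, a gap beyond the scatter. Compound 4 `COc1ccc2cc1CCC(=O)Nc1ccc(S(=O)(=O)C3CC3)c(c1)CN(C)C(=O)[C@@H]2Nc1ccc2c(N)ncc(F)c2c1` has not yet been run. It differs from compound 2 in one place: methoxy in place of cyclopropyl on an aromatic carbon. Going by the values given here, no pair differing only in this way has been measured, so the direction is open. Compound 4 is expected to give about 0.3 h in this assay, between 0.12 h and 0.7 h, with the step of a 1.4-fold lower number from compound 2 to compound 4 (0.16 log units; within the scatter) expected to stay within the scatter.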

Compound 4, half-life: 0.233 h
Compound 4: middle estimate off by 1.3-fold (0.11 log units), on the high side; low and high end bracket the measured number.
By their numbers in this assay, from the lowest: compound 1; then compounds 4, 3 and 2 (each within the scatter of the next).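

Methoxy in place of cyclopropyl on this aromatic carbon, ortho to a fused ring and para to a fused ring, gives a 1.9-fold lower number from compound 2 to compound 4 (0.27 log units; within the scatter) in this assay. This first measured pair differing in one place shows that, at this position, the exchange does not shift the half-life beyond the scatter. Nothing measured here accounts for the step.

From the compounds shown here alone, whether an amine or ethoxy on this carbon would give a number beyond the scatter remains open. So does whether this exchange would stay within the scatter on another aromatic carbon of the shared core.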